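The source may report more compounds than this note shows. Statements on the series, on what has been measured and on what is new or still open speak of the compounds shown alone.

Measured in a functional assay on A-375 cells (Homo sapiens) for antiproliferative activity, read by CCK-8 assay, with a stated time of 72 h; on this read-out lower numbers stand for stronger inhibition and higher numbers for weaker inhibition:
Compound 1 `CCc1ccc(SCc2ccc(/C=C/C(=O)Nc3ccccc3N)cc2)cc1`: "not determined" (no result reported)
Compound 2 `CCc1ccc(SCc2ccc(C(=O)Nc3ccccc3N)cc2)cc1`: 2420 nM
Compound 3 `Nc1ccccc1NC(=O)/C=C/c1ccc(CSc2ccc(F)cc2)cc1`: 3670 nM

Among the measured compounds shown here, only two of the three compounds carry a number in this assay, as compound 1 has the entry "not determined" (no result reported) and gives no basis for comparison. Compound 2 stands at 2420 nM and compound 3 at 3670 nM, and these two values lie within the scatter of each other. The series therefore offers a single level of micromolar-range activity rather than a ranking.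

The next compound to be tested is compound 4 `Cc1cc(C)cc(SCc2ccc(C(=O)Nc3ccccc3N)cc2)c1`, which is related to compound 2 by one change: 3,5-dimethylphenyl in place of 4-ethylphenyl on a sulfur. The 3,5-dimethylphenyl group thus takes the place of the 4-ethylphenyl group on the sulfur, while the rest of the structure stays the same. For the measured compounds named here, no pair of measured compounds differs in one place, so the data hold no direct precedent for this change, and the expectation rests on compound 2 at 2420 nM. In this assay, no shift beyond the scatter is expected, and the estimated 1.0-fold higher number from compound 2 to compound 4 (0.01 log units; within the scatter) is small and has no firm direction. Compound 4 is expected at about 2500 nM, with an estimated range from 1000 nM to 6000 nM.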

Compound 4, half-maximal inhibitory concentration: 3670 nM
Estimate against measurement, compound 4: 1.5-fold (0.17 log units) below; the range from low to high includes it.
By their numbers in this assay, from the lowest: compounds 2, 3 and 4 (each within the scatter of the next).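

In this assay, among the compounds shown here, exchanging the 4-ethylphenyl group for the 3,5-dimethylphenyl group at a sulfur whose other neighbours are a saturated chain carbon gives a 1.5-fold higher number from compound 2 to compound 4 (0.18 log units; within the scatter) and provides the first direct reading at this position. Both groups contain the same count of carbon atoms in one six-membered aromatic ring of carbon only, so this single comparison shows that replacing one ethyl group with two methyl groups leaves the two compounds indistinguishable on this read-out. Nothing available here explains this result, and no cause can be assigned to it.

The compounds shown leave open whether this position would respond to a group of a different kind, such as an amine or a carboxylic acid on the aromatic ring, or to a longer chain in place of the ethyl group. The part of the molecule that joins the carbonyl to the rest also remains unresolved, as compound 1 is recorded as "not determined" (no result reported) and offers no value to set against compound 2.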